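The source may report more compounds than this note shows. Statements on the series, on what has been measured and on what is new or still open speak of the compounds shown alone.

Compound 1 `O=C(/C=C/c1cccc(NC(=O)c2ccccc2Br)c1)c1nc2ccccc2[nH]1` has the highest number of the three compounds in a functional assay on HCT-116 cells (Homo sapiens) for antiproliferative activity, read by MTT assay, with a stated time of 48 h (on this read-out higher numbers stand for weaker inhibition and lower numbers for stronger inhibition), where compound 1 gives 1680 nM; only its step to compound 3 lies beyond the scatter. Compound 2 `O=C(/C=C/c1cccc(NS(=O)(=O)c2ccccc2Cl)c1)c1nc2ccccc2[nH]1` gives 987 nM in this assay, and compound 3 `O=C(/C=C/c1cccc(NS(=O)(=O)c2cccc(Cl)c2)c1)c1nc2ccccc2[nH]1` gives 737 nM. The steps seen so far are a 1.7-fold lower number from compound 1 to compound 2 (0.23 log units; within the scatter), a 2.3-fold lower number from compound 1 to compound 3 (0.36 log units; beyond the scatter) and a 1.3-fold lower number from compound 2 to compound 3 (0.13 log units; within the scatter). Compound 4 `Cc1ccc(S(=O)(=O)Nc2cccc(/C=C/C(=O)c3nc4ccccc4[nH]3)c2)cc1` differs from compound 1 in one place: (4-methylphenyl)sulfonyl in place of (2-bromophenyl)carbonyl on a nitrogen on an aromatic ring. The two measured exchanges of the (2-bromophenyl)carbonyl for a sulfonyl both gave lower numbers, one within and one just beyond the scatter, so a modest move in the same direction is expected here, a 2.0-fold lower number from compound 1 to compound 4 (0.31 log units; beyond the scatter). Compound 4 is therefore estimated at 820 nM, within 400 nM to 1700 nM.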

Compound 4, half-maximal inhibitory concentration: 1990 nM
Compound 4: the middle estimate sits 2.4-fold (0.39 log units) below what was measured, outside the stated range (above it).
By their numbers in this assay, from the lowest: compounds 3, 2, 1 and 4 (each within the scatter of the next, the first and the last beyond it).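

In this assay, a sulfonyl in place of the (2-bromophenyl)carbonyl does not by itself bring a lower number: compound 4, with its (4-methylphenyl)sulfonyl, shows a 1.2-fold higher number from compound 1 to compound 4 (0.07 log units; within the scatter), so it goes against the direction seen with compound 2 and compound 3. The group on the sulfonyl sulfur therefore counts at this position, with a 2.7-fold higher number from compound 3 to compound 4 (0.43 log units; beyond the scatter), the larger step, beyond the scatter, and a 2.0-fold higher number from compound 2 to compound 4 (0.30 log units; within the scatter), within it. Nothing available explains this difference. Still open, going by these compounds, is how a 4-chlorophenyl on the sulfonyl sulfur would read, which would help separate the choice of substituent from its place on the ring. Also open, on these data alone, is how an amine on that ring would read.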